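Amino for Hydroxy in a Series Sitting at the Limit

The compounds below may be only part of what the source reports. "The series", "measured", "known", "first", "only" and "open" are said of these compounds alone.

Of the compounds shown here, three have been measured in a functional assay on HT29-AK cells (Homo sapiens) for cytotoxicity, read by MTT assay, with a stated time of 48 h; on this read-out lower numbers stand for stronger inhibition and higher numbers for weaker inhibition. Compound 1 `Fc1cccc(-c2nc(Nc3cccc(Cl)c3)c3cc(F)ccc3n2)c1` gives only a limit in this assay, > 50000 nM. Compound 2 `Oc1ccc(Nc2nc(-c3cccc(F)c3)nc3ccc(F)cc23)cc1` likewise gives only a limit, > 50000 nM. Compound 3 `Oc1ccccc1Nc1nc(-c2cccc(F)c2)nc2ccc(F)cc12` also stands at a limit, > 50000 nM. Because all three values rest on (the limit of > 50000 nM in this assay, at which 3 of the 3 values shown sit), none of the steps among them can be read: a step that the two limits leave unreadable from compound 1 to compound 2, a step that the two limits leave unreadable from compound 1 to compound 3 and a step that the two limits leave unreadable from compound 2 to compound 3 reveal neither direction nor size.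

Compound 4 `Nc1ccccc1Nc1nc(-c2cccc(F)c2)nc2ccc(F)cc12` differs from compound 3 by amino in place of hydroxy on an aromatic carbon. Among the measured compounds shown here, the measured steps, each swapping one aryl group for another on the same nitrogen, bear on this change only in that every variation so far has left the read-out at the limit, so no readable size is available to carry over. The expected step is a number no higher from compound 3 to compound 4 (the limit leaves the size open), which is to say none beyond the scatter, with the value most likely again reported as a limit. Compound 4 is therefore estimated at 50000 nM, within a range from 20000 nM to 100000 nM.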

Compound 4, half-maximal inhibitory concentration: > 50000 nM
Compound 4 was reported as a limit (the forecaster's own chance of this, stated with the estimate: 85%); the middle value lies on the limit itself.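

Compound 4 gives only a limit, as do compound 1, compound 2 and compound 3, so no step from any of them to compound 4 can be read: the limit of > 50000 nM in this assay, at which 4 of the 4 values shown sit.

The compounds shown leave open whether amino and hydroxy differ at all in this assay, and whether any of these aryl groups on the nitrogen changes the read-out.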